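Methyl for methoxy on a weak sulfonamide inhibitor

This account rests on a few compounds, and the source may have more. Where it says the series, first, only, none or still open, it means among the compounds named here.

Compound 1 `COc1ccc(Br)cc1S(=O)(=O)Nc1cncc(C(N)=O)c1`: 14 nM
Compound 2 `COc1ccc(S(=O)(=O)Nc2cccnc2)c(OC)c1`: 10300 nM
Compound 3 `COc1ccc(C(F)(F)F)cc1S(=O)(=O)Nc1cnc2ccccc2c1`: 26 nM

Three sulfonamides were characterised in an assay on isolated protein for inhibition of alkaline phosphatase, tissue-nonspecific isozyme (Homo sapiens); on this read-out lower numbers stand for stronger inhibition and higher numbers for weaker inhibition. Compound 2 gives the highest number of the three, with compound 3 nearest at a number far lower and compound 1 further still, both gaps well beyond the usual scatter. Compound 1 and compound 3 share a halogen or trifluoromethyl group on the sulfonyl-bearing ring and carry larger heteroaromatic amine parts, whereas compound 2 carries two methoxy groups and a plain pyridyl amine; which of these features accounts for the gap cannot be told from the three numbers alone.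

Compound 4 `COc1cc(C)ccc1S(=O)(=O)Nc1cccnc1` has not yet been measured. It differs from compound 2 as follows: methyl in place of methoxy on an aromatic carbon. Within the data shown here, no measured pair shows this exact change. Given that compound 2 sits at 10300 nM and that the two far stronger compounds carry a small non-oxygen substituent at the comparable position, a modest step toward a lower number, not a large one, is expected in this assay. The estimate for compound 4 is 3500 nM, with a range of 800 nM to 15000 nM, which would mean an expected step of a 2.9-fold lower number from compound 2 to compound 4 (0.47 log units; beyond the scatter).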

Compound 4, half-maximal inhibitory concentration: 896 nM
Compound 4: middle estimate off by 3.9-fold (0.59 log units), on the high side; the range from low to high includes it.
By their numbers in this assay, from the lowest: compounds 1 and 3 (each within the scatter of the next); then compound 4; then compound 2.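

In this assay, putting methyl in place of methoxy on this aromatic carbon, para to a large group and meta to a methoxy group, gives an 11-fold lower number from compound 2 to compound 4 (1.06 log units; beyond the scatter), a large step for the exchange of a single small substituent. Among these compounds, this pair is the first to differ in one place, and it shows that this position alone can move the read-out substantially while the other methoxy group and the plain pyridyl amine part stay unchanged. The pair cannot separate the loss of the oxygen from the arrival of the methyl, and no measurement available here gives a reason for the step.

The compounds shown leave open how a hydrogen atom, a chlorine atom, an ethyl group or an amine at this position would compare with methyl and methoxy. Going by these compounds, compound 1 and compound 3 each differ from compound 4 in more than one place, so it also remains open whether the same exchange would give a step of similar size on their cores.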